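The source may report more compounds than this note shows. Statements on the series, on what has been measured and on what is new or still open speak of the compounds shown alone.

Of the compounds shown here, two sharing one core have been measured in a functional assay on A549 cells (Homo sapiens) for antiproliferative activity, read by MTT assay, with a stated time of 72 h; on this read-out lower numbers stand for stronger inhibition and higher numbers for weaker inhibition. Compound 1 (`COc1cc(CCc2ccccc2Cl)cc(OC)c1O`) gives 2130 nM, and compound 2 (`COc1cc(CCc2ccc(Cl)cc2)cc(OC)c1O`) gives 22900 nM. Compound 2 therefore holds the higher of the two numbers, and its gap to compound 1 lies beyond the usual scatter. These two compounds are not joined by a change in one place, so their values show only that gap.

Compound 3 (`COc1cc(CCc2ccc(Cl)cc2Cl)cc(OC)c1O`) starts from compound 2 and carries one change: chloro in place of hydrogen on an aromatic carbon, ortho to a large group and meta to a chloro group. Compound 3 keeps the chloro group of compound 2 and gains one placed as in compound 1. The expectation rests on compound 1, which has a chloro group ortho to a large group and gives 2130 nM. A move towards that lower number is therefore expected in this assay, probably beyond the scatter, but not all the way. The expected size of this move is a 3.8-fold lower number from compound 2 to compound 3 (0.58 log units; beyond the scatter). The estimated value for compound 3 is 6000 nM, with an expected range from 1800 nM to 20000 nM.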

Compound 3, half-maximal inhibitory concentration: 3840 nM
For compound 3 the middle estimate is 1.6-fold (0.19 log units) above the measured one; the measured number falls inside the stated range.
By their numbers in this assay, from the lowest: compounds 1 and 3 (each within the scatter of the next); then compound 2.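

Within this assay the change from hydrogen to chloro on the aromatic carbon ortho to a large group gives a 6.0-fold lower number from compound 2 to compound 3 (0.78 log units; beyond the scatter) and so shows that this position responds to a chloro group even when the chloro group of compound 2 is already present. Compound 1 had shown only that a single chloro group placed there goes with a low number, whereas the further step of a 1.8-fold higher number from compound 1 to compound 3 (0.26 log units; within the scatter) shows that the second chloro group of compound 3 brings no change beyond the scatter, so among these three compounds the low numbers go with the chloro group at this position. Nothing given here explains why this position matters.

As far as these compounds go, it remains open whether the response belongs to chloro itself or would also appear with a fluoro, methyl or methoxy group on the same aromatic carbon. It is equally unsettled how far the result holds if the two-carbon chain joining the aromatic rings is replaced by an amide, or if the hydroxyl group of the shared core gives way to a methoxy group.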